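Cutting a Dodecyl Chain Down to Methyl

This account rests on a few compounds, and the source may have more. Where it says the series, first, only, none or still open, it means among the compounds named here.

Compound 1, `CCCCCCCCCCCCOc1ccc(C(=O)/C=C/c2c(/C=C/c3ccc(OC)cc3)cc(OC)cc2OC)cc1`, carries a dodecyl chain on an oxygen of one aromatic ring. Going by the values given here, in a functional assay on B16-F10 cells (Mus musculus) for antiproliferative activity, read by MTT assay, with a stated time of 48 h (on this read-out higher numbers stand for weaker inhibition and lower numbers for stronger inhibition), compound 1 gives 12.7 ug/mL, the highest of the three numbers measured so far. Compound 2, `CCCCOc1ccc(C(=O)/C=C/c2c(/C=C/c3ccc(OC)cc3)cc(OC)cc2OC)cc1`, differs from it by hydrogen in place of octyl on a saturated chain carbon, four bonds along the chain from an oxygen on an aromatic ring; in this assay compound 2 gives 5.3 ug/mL, and the step of a 2.4-fold lower number from compound 1 to compound 2 (0.38 log units; beyond the scatter) is modest but beyond the scatter. Compound 3, `COc1ccc(/C=C/c2cc(OC)cc(OC)c2/C=C/C(=O)c2ccc(N)cc2)cc1`, has amino in place of butoxy on an aromatic carbon and gives 2.8 ug/mL in this assay; the step of a 1.9-fold lower number from compound 2 to compound 3 (0.28 log units; within the scatter) lies within the scatter.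

Compound 4, `COc1ccc(/C=C/c2cc(OC)cc(OC)c2/C=C/C(=O)c2ccc(OC)cc2)cc1`, is compound 1 with hydrogen in place of undecyl on a saturated chain carbon bound to an oxygen on an aromatic ring; the same difference, cut one bond further out, reads dodecyl to methyl. Among the compounds with values here, the step of a 2.4-fold lower number from compound 1 to compound 2 (0.38 log units; beyond the scatter) is the only measured change that removes part of this chain, and compound 4 removes more of it. A further modest lowering of the number is therefore expected, likely beyond the scatter but not large. Compound 4 is expected to give 4 ug/mL in this assay, within a range from 2 ug/mL to 9 ug/mL. That estimate for compound 4 amounts to a step of a 3.2-fold lower number from compound 1 to compound 4 (0.50 log units; beyond the scatter).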

Compound 4, half-maximal inhibitory concentration: 5.8 ug/mL
Beside the measured number, compound 4's estimate is 1.5-fold (0.16 log units) below it, and the stated range covers the measured number.
By their numbers in this assay, from the lowest: compounds 3, 2 and 4 (each within the scatter of the next, the first and the last beyond it); then compound 1.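

The chain on this oxygen does not act evenly along its length. Cutting it from dodecyl to methyl gives a 2.2-fold lower number from compound 1 to compound 4 (0.34 log units; beyond the scatter) and so separates compound 4 from compound 1 by about as much as butyl did, while the further cut from butyl to methyl, a 1.1-fold higher number from compound 2 to compound 4 (0.04 log units; within the scatter), leaves compound 2 and compound 4 indistinguishable, so among these compounds the whole measured change lies between the dodecyl and the shorter chains. The group on this aromatic carbon also comes into sharper view, as a 2.1-fold higher number from compound 3 to compound 4 (0.32 log units; beyond the scatter) puts the amino compound apart from the methoxy compound beyond the scatter, although a 1.9-fold lower number from compound 2 to compound 3 (0.28 log units; within the scatter) did not separate it from the butoxy compound, and compound 2 sits within the scatter of both. Nothing among the data shown offers a reason for any of these steps.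

The compounds shown leave open where between butyl and dodecyl the number begins to climb, which a hexyl or an octyl chain on the same oxygen would help to place. They also leave open whether amino stands alone on this carbon or whether a hydroxyl, a dimethylamino group or a carboxylic acid would fall with it rather than with the alkoxy groups.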